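Aryl-piperazine variation in the oxazole series

The source may report more compounds than this note shows. Statements on the series, on what has been measured and on what is new or still open speak of the compounds shown alone.

Measured compounds:
compound 1, `CCCc1nc(-c2ccccc2)c(CNCCN2CCN(c3cccc(C)c3)CC2)o1`: 43.1%
compound 2, `CCCc1nc(-c2ccccc2)c(CNCCN2CCN(c3ccc(C(F)(F)F)cc3)CC2)o1`: 58.7%
compound 3, `CCCc1nc(-c2ccccc2)c(CNCCN2CCN(c3ccccc3)CC2)o1`: 54.3%

In an assay on HEK293 cells for inhibition of Voltage-dependent T-type calcium channel subunit alpha-1G (Homo sapiens), read by fluorescence, tested at 10 uM (on this read-out lower numbers stand for less inhibition and higher numbers for more inhibition at the one concentration tested (going by the name of the read-out)), compound 3 gives 54.3%, the second highest of the three numbers. The step of a number 4.4 percentage points lower from compound 2 to compound 3 (within the scatter) is within the scatter, so the two cannot be ordered; the step of a number 11.2 percentage points higher from compound 1 to compound 3 (beyond the scatter) is beyond the scatter and modest.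

Compound 4, `CCCc1nc(-c2ccccc2)c(CNCCN2CCN(c3cccc(Cl)c3)CC2)o1`, has not been measured. Its change from compound 3 is chloro in place of hydrogen on an aromatic carbon.

Going by the values given here, two measured steps touch this question. The step of a number 11.2 percentage points higher from compound 1 to compound 3 (beyond the scatter) shows that a methyl at this same ring position, read in the reverse direction, lowers the number modestly. The step of a number 4.4 percentage points lower from compound 2 to compound 3 (within the scatter) shows a trifluoromethyl elsewhere on the ring making no difference beyond the scatter. No chloro appears among the measured compounds. Taken together, the expectation is for a small step, most likely downward, of a size that may stay within the scatter: the estimated step is a number 5.3 percentage points lower from compound 3 to compound 4 (within the scatter).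

Compound 4 is therefore estimated at 49%, with a range from 35% to 63%.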

Compound 4, a percentage reported as inhibition, at one concentration (the size of the read-out at that concentration, not a potency): 51.2%
Compound 4: middle estimate off by 2.2 percentage points, on the low side, within the range that was stated.
By their numbers in this assay, from the lowest: compounds 1, 4, 3 and 2 (each within the scatter of the next, the first and the last beyond it).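

In this assay, chloro at this place, on an aromatic carbon meta to a large group, leaves the number unresolved from hydrogen (a number 3.1 percentage points lower from compound 3 to compound 4 (within the scatter)), whereas methyl at the same place was separated from hydrogen (a number 11.2 percentage points higher from compound 1 to compound 3 (beyond the scatter)). Compound 4 also cannot be separated from either neighbour, neither with chloro in place of methyl (a number 8.1 percentage points higher from compound 1 to compound 4 (within the scatter)) nor with 3-chlorophenyl in place of 4-(trifluoromethyl)phenyl (a number 7.5 percentage points lower from compound 2 to compound 4 (within the scatter)), although compound 1 and compound 2 themselves lie beyond the scatter of each other. Nothing available here offers an explanation for these steps.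

Open, going by these compounds, is what a methoxy, a nitrile or an amine would give at this same place. Also open, on these data alone, is whether these single-concentration numbers would hold up as potency differences across a concentration series.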